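Triazole nitrogen substituent series: expectation for compound 4

The source may report more compounds than this note shows. Statements on the series, on what has been measured and on what is new or still open speak of the compounds shown alone.

Going by the values given here, compound 3 `CN(CCNCc1cn(C(C)(C)C)nn1)CCNc1ccnc2cc(Cl)ccc12` gives 56000 nM in a functional assay on HCC827 cells (Homo sapiens) for antiproliferative activity, read by sulforhodamine B assay, with a stated time of 72 h (on this read-out higher numbers stand for weaker inhibition and lower numbers for stronger inhibition), and stands second highest of the three numbers measured so far; compound 1 `C#CCNCCN(C)CCNc1ccnc2cc(Cl)ccc12` gives 105000 nM and compound 2 `CN(CCNCc1cn(-c2ccc(F)cc2)nn1)CCNc1ccnc2cc(Cl)ccc12` gives 19000 nM. Compound 4 `CN(CCNCc1cn(CCCn2nn[nH]c2=O)nn1)CCNc1ccnc2cc(Cl)ccc12` is not yet measured; it differs from compound 3 by a group of 9 heavy atoms (4 carbon, 4 nitrogen, 1 oxygen; one five-membered aromatic ring with 4 hetero atoms) in place of a group of 4 heavy atoms (4 carbon; no ring), on an aromatic nitrogen. The step that bears on this change is a 2.9-fold higher number from compound 2 to compound 3 (0.47 log units; beyond the scatter), which swaps the group on the same aromatic nitrogen; the step of a 1.9-fold lower number from compound 1 to compound 3 (0.27 log units; within the scatter) concerns another place and is within the scatter. As the incoming group in compound 4 carries a ring, like the group in compound 2, a modest lowering of the number is expected. Compound 4 is estimated at 30000 nM, with a range of 12000 nM to 80000 nM, an expected step of a 1.9-fold lower number from compound 3 to compound 4 (0.27 log units; within the scatter).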

Compound 4, half-maximal inhibitory concentration: > 200000 nM
Compound 4: no number, only a limit; the forecaster's own chance of this, stated with the estimate: 5%; middle value at least 6.6-fold (0.82 log units) from the limit.
By their numbers in this assay, from the lowest: compound 2; then compounds 3 and 1 (each within the scatter of the next). At a limit, above all of these: compound 4.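

In this assay compound 4 gives no number, only a limit: the limit of > 200000 nM in this assay, at which 1 of the 4 values shown sits.

The new group on this aromatic nitrogen gives an at least 3.5-fold higher number from compound 3 to compound 4 (0.55 log units; beyond the scatter), and against the 4-fluorophenyl group it gives an at least 10-fold higher number from compound 2 to compound 4 (1.02 log units; beyond the scatter). A ring in the group is therefore no guide at this position: compound 2 and compound 4 both carry one, yet they stand at opposite ends of the series.

On these data alone, whether the rise follows the ring with 4 hetero atoms, its hydrogen-bond donor or the chain that carries it stays open. A carboxylic acid or an amine at the end of the same chain would help to separate these.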